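Swapping one halogen for another at the far end of compound 3

The compounds below may be only part of what the source reports. "The series", "measured", "known", "first", "only" and "open" are said of these compounds alone.

Compound 1, `O=c1[nH]c(=O)n([C@H]2C[C@H](O)[C@@H](CO)O2)cc1-c1cn(-c2c(F)cccc2F)nn1`: in an ADME assay on HEL cells (Homo sapiens) for cytotoxicity, read by cell counting, with a stated time of 3 days (a lower number here means that less compound is tolerated, a higher number that more compound is tolerated), compound 1 gives >= 10000 nM, which is a limit of the assay.
Compound 2, `CC(C)(C)c1ccc(-n2cc(-c3cn([C@H]4C[C@H](O)[C@@H](CO)O4)c(=O)[nH]c3=O)nn2)cc1`: in this assay compound 2 gives 230000 nM.
Compound 3, `O=c1[nH]c(=O)n([C@H]2C[C@H](O)[C@@H](CO)O2)cc1-c1cn(-c2ccc(Cl)cc2)nn1`: in this assay compound 3 gives > 240000 nM, which is a limit of the assay.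

Compound 3 therefore stands at the upper limit of this assay, with no exact number behind it (the limit of > 240000 nM in this assay, at which 1 of the 3 values shown sits). Compound 1 also sits at a limit, a lower one (the limit of >= 10000 nM in this assay, at which 1 of the 3 values shown sits). Only compound 2 has a numeric value. The step of an at least 1.0-fold higher number from compound 2 to compound 3 (0.01 log units; that floor lies within the scatter); the steps a step that the limit leaves unreadable from compound 1 to compound 2 and a step that the two limits leave unreadable from compound 1 to compound 3.

Compound 4, `O=c1[nH]c(=O)n([C@H]2C[C@H](O)[C@@H](CO)O2)cc1-c1cn(-c2ccc(Br)cc2)nn1`, is made from compound 3 by a single exchange: bromo in place of chloro on an aromatic carbon. Within the data shown here, the one step that bears on it, from compound 2 to compound 3, exchanged one group on the same aromatic carbon and stayed within the scatter, so no shift beyond the scatter is expected in this assay, and compound 4 is estimated to show a number no higher from compound 3 to compound 4 (the limit leaves the size open). Compound 4 is thus expected to give about 240000 nM, in the range 120000 nM to 480000 nM, most likely again reported as a limit.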

Compound 4, minimum cytotoxic concentration: >= 44000 nM
Compound 4 ended at the assay's limit (the forecaster's own chance of this, stated with the estimate: 70%); the middle value does not contradict the limit.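

In this assay compound 4 gives >= 44000 nM, which is a limit of the assay. The steps from compound 1, compound 2 and compound 3 to compound 4 cannot be read. The compounds shown leave open how far bromo in place of chloro shifts the tolerated concentration, if at all.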